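Swapping a cyclic acetal for an open one on the sulfur side chain

This account rests on a few compounds, and the source may have more. Where it says the series, first, only, none or still open, it means among the compounds named here.

Compound 1 `c1ccc(-c2nc(SCC3CCCCO3)[nH]c2-c2ccccc2)cc1` is a potent inhibitor in an assay on microsomes from liver for inhibition of sterol O-acyltransferase 1 (Rattus norvegicus) (a lower number here means a stronger inhibitor, a higher number a weaker inhibitor), where compound 1 gives 210 nM. Compound 2 `c1ccc(-c2nc(SCCC3OCCCO3)[nH]c2-c2ccccc2)cc1` has the highest number of the two, as in this assay compound 2 gives 730 nM; the step of a 3.5-fold higher number from compound 1 to compound 2 (0.54 log units; beyond the scatter) is the only one measured. Compound 3 `COC(CSc1nc(-c2ccccc2)c(-c2ccccc2)[nH]1)OC` differs from compound 2 by a group of 5 heavy atoms (3 carbon, 2 oxygen; no ring) in place of a group of 7 heavy atoms (5 carbon, 2 oxygen; one six-membered non-aromatic ring with 2 hetero atoms), on a saturated chain carbon bound to a sulfur. Among the measured compounds shown here, no measured step covers such a change, so compound 3 is expected to stay close to compound 2, with a step of a 1.2-fold lower number from compound 2 to compound 3 (0.09 log units; within the scatter) within the scatter. The estimate for compound 3 is 600 nM, ranging from 200 nM to 2000 nM.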

Compound 3, half-maximal inhibitory concentration: 580 nM
Beside the measured number, compound 3's estimate is 1.0-fold (0.01 log units) above it, and the stated range covers the measured number.
By their numbers in this assay, from the lowest: compound 1; then compounds 3 and 2 (each within the scatter of the next).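

In this assay, dimethoxymethyl and the ring it replaces in compound 2 cannot be told apart (a 1.3-fold lower number from compound 2 to compound 3 (0.10 log units; within the scatter)), so closing these two oxygens into a ring shows no measurable effect here. Oxan-2-yl on the same saturated chain carbon bound to a sulfur still gives the lower number (a 2.8-fold higher number from compound 1 to compound 3 (0.44 log units; beyond the scatter)). Nothing at hand explains this order. Still open, as far as these compounds go, is how an amine or a carboxylic acid would compare at this place, and whether a longer chain carrying dimethoxymethyl would shift the number.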